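The source may report more compounds than this note shows. Statements on the series, on what has been measured and on what is new or still open speak of the compounds shown alone.

Compound 1, with the structure `Cc1ccnc2nc(-c3cccc4ccccc34)cc(O)c12`, gives 20 nM in a functional assay on PC-3 cells (Homo sapiens) for antiproliferative activity; on this read-out higher numbers stand for weaker inhibition of growth and lower numbers for stronger inhibition of growth. Adding a methyl group on its core yields compound 2, `Cc1cc(C)c2c(O)cc(-c3cccc4ccccc34)nc2n1`, which gives 759 nM; the change methyl in place of hydrogen on an aromatic carbon thus produces a 38-fold higher number from compound 1 to compound 2 (1.58 log units; beyond the scatter). Compound 3, `Cc1ccc2c(O)cc(-c3ccc4ccccc4c3)nc2n1`, carries the same atoms as compound 1 joined differently; the difference between the two cores is not broken down here. In this assay compound 3 gives 2630 nM. Compound 4, `Cc1cc(C)c2c(O)cc(-c3ccc4ccccc4c3)nc2n1`, arises from compound 3 by methyl in place of hydrogen on an aromatic carbon, the same kind of change as from compound 1 to compound 2, though the place differs: here the methyl stands ortho to a fused ring and opposite the ring nitrogen, rather than next to the ring nitrogen and para to a fused ring. Given the large step from compound 1 to compound 2, a smaller weakening is expected for compound 4, estimated as a 3.0-fold higher number from compound 3 to compound 4 (0.48 log units; beyond the scatter). Compound 4 is therefore estimated at 8000 nM, between 2500 nM and 30000 nM.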

Compound 4, concentration for 50% growth inhibition: 5500 nM
For compound 4 the middle estimate is 1.5-fold (0.16 log units) above the measured one; measured number inside the range.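

In this assay the methyl in place of hydrogen on an aromatic carbon gives a 2.1-fold higher number from compound 3 to compound 4 (0.32 log units; beyond the scatter) and so again weakens growth inhibition. The direction of the change carries over from one core to the other, but its size does not: the same change on two cores in this assay, a 38-fold higher number (1.58 log units; beyond the scatter) from compound 1 to compound 2 and a 2.1-fold higher number (0.32 log units; beyond the scatter) from compound 3 to compound 4, 18-fold (1.26 log units) apart, beyond the scatter of two such steps. The methyl stands at a different place in the two pairs and the cores differ too, so these pairs do not show which of these sets the size, and two pairs make no rule for the series.

The compounds shown leave open how a group other than methyl, such as an amine or a longer chain, would act at either place. They also leave open whether a methyl at one same place would give steps of like size on both cores.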